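Moving the nitro group: compound 3 to compound 4

The source may hold more compounds than are shown below. What is called first, only, known or untested is meant among the compounds shown, and "the series" means these compounds.

Measured in a functional assay on NCI-H460 cells (Homo sapiens) for antiproliferative activity; on this read-out lower numbers stand for stronger inhibition and higher numbers for weaker inhibition:
- compound 1 `N#CN/C(=N\CCCCCCOc1ccccc1)Nc1ccncc1`: 52 nM
- compound 2 `COc1cccc(OCCCCCC/N=C(\NC#N)Nc2ccncc2)c1`: 38 nM
- compound 3 `N#CN/C(=N\CCCCCCOc1cccc([N+](=O)[O-])c1)Nc1ccncc1`: 74 nM

Compound 3 stands level with the other two within the scatter: a 1.4-fold higher number from compound 1 to compound 3 (0.15 log units; within the scatter) and a 1.9-fold higher number from compound 2 to compound 3 (0.29 log units; within the scatter). Compound 4 `N#CN/C(=N\CCCCCCOc1ccc([N+](=O)[O-])cc1)Nc1ccncc1` has not been measured. It differs from compound 3 by one change: 4-nitrophenyl in place of 3-nitrophenyl on an oxygen on a saturated carbon. For the measured compounds named here, no measured step relocates a group, so the evidence is indirect. Nitro for hydrogen gave a 1.4-fold higher number from compound 1 to compound 3 (0.15 log units; within the scatter) and methoxy for hydrogen gave a 1.4-fold lower number from compound 1 to compound 2 (0.14 log units; within the scatter). Neither replacement moved the number beyond the scatter, so no step beyond it is expected in this assay. The expected step is a 1.3-fold lower number from compound 3 to compound 4 (0.13 log units; within the scatter). For compound 4 the estimated value is 55 nM. The expected range for compound 4 runs from 20 nM to 150 nM.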

Compound 4, half-maximal inhibitory concentration: 590 nM
Compound 4: middle estimate off by 11-fold (1.03 log units), on the low side, outside the stated range (above it).
By their numbers in this assay, from the lowest: compounds 2, 1 and 3 (each within the scatter of the next); then compound 4.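

In this assay the outcome depends on where the nitro group sits, not only on its presence: 4-nitrophenyl in place of 3-nitrophenyl, with the same atoms, gives (an 8.0-fold higher number from compound 3 to compound 4 (0.90 log units; beyond the scatter)). For the compounds shown here, compound 4 also separates from the compounds carrying no nitro group (an 11-fold higher number from compound 1 to compound 4 (1.05 log units; beyond the scatter); a 16-fold higher number from compound 2 to compound 4 (1.19 log units; beyond the scatter)), giving the first steps beyond the scatter. No measurement shown accounts for this change.

The compounds shown leave open whether the higher number follows the nitro group itself or any group in that place. A 4-methoxyphenyl or 4-aminophenyl compound would separate these two readings.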